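Shortening one ester of compound 3: expected effect

The source may report more compounds than this note shows. Statements on the series, on what has been measured and on what is new or still open speak of the compounds shown alone.

In an assay on isolated protein (strain albino) for inhibition of Voltage-dependent L-type calcium channel subunit alpha-1C (Cavia porcellus) (on this read-out higher numbers stand for weaker inhibition and lower numbers for stronger inhibition), compound 3 `CCOC(=O)C1=C(C)NC(C)=C(C(=O)OCC)C1c1cc(=O)cc(C)o1` gives 35900 nM, the highest of the three numbers recorded. Compound 2 `CCOC(=O)C1=C(C)NC(C)=C(C(=O)OCC)C1c1cc(=O)cc(-c2ccccc2)o1` gives 3240 nM, and compound 1 `COC(=O)C1=C(C)NC(C)=C(C(=O)OC)C1c1ccc(-c2cc(=O)cc(-c3ccccc3)o2)cc1` gives 4710 nM. Among the compounds with values here, the only single-point step among them, an 11-fold higher number from compound 2 to compound 3 (1.04 log units; beyond the scatter), concerns the aryl substituent and not the ester. Compound 4 `CCOC(=O)C1=C(C)NC(C)=C(C(=O)OC)C1c1cc(=O)cc(C)o1` differs from compound 3 by hydrogen in place of methyl on a saturated chain carbon bound to an oxygen next to a carbonyl group. Within the data shown here, no measured pair isolates this ester change; compound 1 carries two methyl esters but also a different aryl group, and no single-change step links it to compound 2. For compound 4 the step is therefore expected to be a 1.1-fold lower number from compound 3 to compound 4 (0.02 log units; within the scatter), within the scatter. Compound 4 is estimated at 34000 nM in this assay, with a range from 15000 nM to 80000 nM.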

Compound 4, half-maximal inhibitory concentration: 1630 nM
Compound 4: the middle estimate sits 21-fold (1.32 log units) above what was measured; the measured number lies below the stated range.
By their numbers in this assay, from the lowest: compounds 4, 2 and 1 (each within the scatter of the next, the first and the last beyond it); then compound 3.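

In this assay, ethoxy to methoxy on one ester gives a 22-fold lower number from compound 3 to compound 4 (1.34 log units; beyond the scatter), so this position responds strongly to the loss of a single methyl. The earlier step, an 11-fold higher number from compound 2 to compound 3 (1.04 log units; beyond the scatter), showed only that the phenyl to methyl change matters, and said nothing about the ester. Nothing on hand accounts for the size of the new step.

On these data alone, whether the same shortening has a comparable effect with the phenyl of compound 2 in place remains open. So does the response of this ester position to a longer chain, such as propyl, or to a terminal amine.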